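The source may hold more compounds than are shown below. What is called first, only, known or untested is meant among the compounds shown, and "the series" means these compounds.

Measured in a functional assay on GOTO cells (Homo sapiens) for cytotoxicity, read by MTT assay, with a stated time of 3 days; on this read-out higher numbers stand for weaker inhibition and lower numbers for stronger inhibition:
- compound 1 `CNc1nc(SCc2nc3ccccc3[nH]2)nc(-c2ccccc2)c1C#N`: 3.28 nM
- compound 2 `N#Cc1c(NC(N)=O)nc(SCc2nc3ccccc3[nH]2)nc1-c1ccccc1`: 11.3 nM
- compound 3 `N#Cc1c(-c2ccccc2)nc(SCc2nc3ccccc3[nH]2)nc1N1CCNCC1`: 3.7 nM

Compound 3 sits within the scatter of compound 1 (a 1.1-fold higher number from compound 1 to compound 3 (0.05 log units; within the scatter)), and the other step reaching it is modest (a 3.1-fold lower number from compound 2 to compound 3 (0.48 log units; beyond the scatter)). Compound 4 `CN1CCN(c2nc(SCc3nc4ccccc4[nH]3)nc(-c3ccccc3)c2C#N)CC1` turns piperazin-1-yl into 4-methylpiperazin-1-yl, methyl in place of hydrogen on an amine nitrogen in a ring. For the measured compounds named here, no measured pair tests this change directly. The nearest evidence is the swap of methylamino for piperazin-1-yl (a 1.1-fold higher number from compound 1 to compound 3 (0.05 log units; within the scatter)), while only the ureido compound 2 stands apart (a 3.4-fold higher number from compound 1 to compound 2 (0.54 log units; beyond the scatter)). No step beyond the scatter is therefore expected in this assay, in either direction. The estimated step is a 1.0-fold higher number from compound 3 to compound 4 (0.01 log units; within the scatter). Compound 4 is expected at 3.8 nM, with an estimated range of 1.5 nM to 10 nM.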

Compound 4, half-maximal inhibitory concentration: 3.37 nM
The estimate for compound 4 lay 1.1-fold (0.05 log units) above the measured number; low and high end bracket the measured number.
By their numbers in this assay, from the lowest: compounds 1, 4 and 3 (each within the scatter of the next); then compound 2.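

In this assay, the first direct test at this position shows that methyl on the amine nitrogen in the ring leaves the number within the scatter (a 1.1-fold lower number from compound 3 to compound 4 (0.04 log units; within the scatter)). The 4-methylpiperazin-1-yl group also stands within the scatter of methylamino (a 1.0-fold higher number from compound 1 to compound 4 (0.01 log units; within the scatter)), while the ureido compound stays apart (a 3.4-fold lower number from compound 2 to compound 4 (0.53 log units; beyond the scatter)). Nothing measured here explains why these numbers agree. The compounds shown leave open whether an acetyl group or a longer chain on that ring nitrogen would also stay within the scatter. They also leave open whether a carboxylic acid there would.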